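Amine swap on the propyl chain: notes toward compound 4

The source may hold more compounds than are shown below. What is called first, only, known or untested is meant among the compounds shown, and "the series" means these compounds.

Measured so far:
compound 1 `O=c1cc(-c2ccccc2)oc2cc(OCc3ccccc3)c(OCCCN3CCCC3)c(O)c12`: > 100000 nM
compound 2 `CN1CCN(CCCOc2c(OCc3ccccc3)cc3oc(-c4ccccc4)cc(=O)c3c2O)CC1`: 4100 nM
compound 3 `COc1cc2oc(-c3ccccc3)cc(=O)c2c(O)c1OCCCN1CCCC1`: 6500 nM

In a functional assay on BCG823 cells (Homo sapiens) for antiproliferative activity, read by MTT assay, with a stated time of 48 h (on this read-out higher numbers stand for weaker inhibition and lower numbers for stronger inhibition), compound 1 gives > 100000 nM, which is a limit of the assay and not a number (the limit of > 100000 nM in this assay, at which 1 of the 3 values shown sits). Compound 2 gives 4100 nM and compound 3 gives 6500 nM; these two lie within the usual scatter of each other. Compound 2 differs from compound 1 by 4-methylpiperazin-1-yl in place of pyrrolidin-1-yl on a saturated chain carbon, three bonds along the chain from an oxygen on an aromatic ring, a change that made an at least 24-fold lower number from compound 1 to compound 2 (1.38 log units; beyond the scatter). The cores of compound 1 and compound 3 differ by hydrogen in place of phenyl on a saturated chain carbon bound to an oxygen on an aromatic ring, with an at least 15-fold lower number from compound 1 to compound 3 (1.18 log units; beyond the scatter).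

Compound 4 `COc1cc2oc(-c3ccccc3)cc(=O)c2c(O)c1OCCCN1CCN(C)CC1` is not yet measured in this assay. It differs from compound 3 by 4-methylpiperazin-1-yl in place of pyrrolidin-1-yl on a saturated chain carbon, three bonds along the chain from an oxygen on an aromatic ring, the same change as between compound 1 and compound 2, at the same place. The step from compound 3 to compound 4 is expected to be smaller than the earlier one, roughly a 3.3-fold lower number from compound 3 to compound 4 (0.51 log units; beyond the scatter), because compound 3 gives 6500 nM rather than a limit, so less room to the same endpoint is expected. Compound 4 is therefore expected near 2000 nM in this assay, between 600 nM and 6500 nM.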

Compound 4, half-maximal inhibitory concentration: 31300 nM
Beside the measured number, compound 4's estimate is 16-fold (1.19 log units) below it, outside the stated range (above it).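

In this assay the swap to 4-methylpiperazin-1-yl does not carry over from the core of compound 1 to the core of compound 3, and its direction reverses, with a 4.8-fold higher number from compound 3 to compound 4 (0.68 log units; beyond the scatter): the same change on two cores in this assay, an at least 24-fold lower number (1.38 log units; beyond the scatter) from compound 1 to compound 2 and a 4.8-fold higher number (0.68 log units; beyond the scatter) from compound 3 to compound 4, at least 110-fold (2.06 log units) apart, beyond the scatter of two such steps

The other change, hydrogen in place of phenyl on a saturated chain carbon bound to an oxygen on an aromatic ring, depends on the amine in the same way, with a 7.6-fold higher number from compound 2 to compound 4 (0.88 log units; beyond the scatter): the same change on two cores in this assay, an at least 15-fold lower number (1.18 log units; beyond the scatter) from compound 1 to compound 3 and a 7.6-fold higher number (0.88 log units; beyond the scatter) from compound 2 to compound 4, at least 110-fold (2.06 log units) apart, beyond the scatter of two such steps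

Compound 1 stands at a limit of the assay and not a number, which leaves the full size of these gaps unfixed, and the four compounds show that the two changes do not add up here, but not why: the limit of > 100000 nM in this assay, at which 1 of the 4 values shown sits.

Still open, as far as these compounds go, is whether the reversal holds for another amine on the propyl chain, such as morpholine or piperidine, on both cores. Also open, from the compounds shown here alone, is whether a longer chain, such as a butyl chain carrying the same two amines, behaves the same way.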